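The source may hold more compounds than are shown below. What is called first, only, known or untested is meant among the compounds shown, and "the series" means these compounds.

Compound 2 `Nc1ccccc1NC(=O)/C=C/c1ccc(Cn2cnc3c(Nc4ccccc4)nc(Cl)nc32)cc1` gives 41.9% in a functional assay on HepG2 cells (Homo sapiens) for antiproliferative activity, read by CCK-8 assay, with a stated time of 72 h, tested at 8 uM (on this read-out lower numbers stand for a weaker effect and higher numbers for a stronger effect at the one concentration tested), the lower of the two numbers measured here; compound 1 `Nc1ccccc1NC(=O)c1ccc(Cn2cnc3c(NCc4ccccc4)nc(Cl)nc32)cc1` gives 62.8%, a gap beyond the usual scatter. Compound 3 `Nc1ccccc1NC(=O)/C=C/c1ccc(Cn2cnc3c(NCc4ccccc4)nc(Cl)nc32)cc1` has not yet been measured. It differs from compound 2 in one place: benzyl in place of phenyl on a nitrogen on an aromatic ring. Within the data shown here, compound 1 carries the same benzylamino group, though on a different linker, so no direct step is available. A moderate rise is expected in this assay, with an estimated step of a number 12.1 percentage points higher from compound 2 to compound 3 (beyond the scatter) from compound 2 to compound 3. Compound 3 is therefore estimated at 54%, within 38% to 70%.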

Compound 3, a percentage reported as inhibition, at one concentration (the size of the read-out at that concentration, not a potency): 37.7%
Compound 3: the middle estimate sits 16.3 percentage points above what was measured; measured number outside the range, below it.
By their numbers in this assay, from the lowest: compounds 3 and 2 (each within the scatter of the next); then compound 1.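

In this assay, the anilino to benzylamino change on the ethenyl linker gives a step within the scatter (a number 4.2 percentage points lower from compound 2 to compound 3 (within the scatter)). With benzylamino held fixed, the first direct linker comparison shows a step beyond the scatter: 2-((2-aminophenyl)carbamoyl)ethenyl in place of (2-aminophenyl)carbamoyl on an aromatic carbon (a number 25.1 percentage points lower from compound 1 to compound 3 (beyond the scatter)). Nothing available accounts for either step. Still open, as far as these compounds go, is whether the anilino to benzylamino change would give a similar step on the (2-aminophenyl)carbamoyl linker of compound 1. Also open, from the compounds shown here alone, is how a longer chain, such as phenethylamino, would read at this nitrogen.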